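The source may hold more compounds than are shown below. What is called first, only, known or untested is meant among the compounds shown, and "the series" means these compounds.

Measured in a functional assay on RS4-11 cells (Homo sapiens) for inhibition, read by CCK-8 assay, with a stated time of 48 h; a lower number here means a stronger inhibitor, a higher number a weaker inhibitor:
- Compound 1 `O=S(=O)(NCCNC(=S)Nc1cc(C(F)(F)F)cc(C(F)(F)F)c1)c1ccc(-c2ccccc2OCc2cccc(O)c2)s1`: 12000 nM
- Compound 2 `O=S(=O)(NCCNC(=S)Nc1cc(C(F)(F)F)cc(C(F)(F)F)c1)c1ccc(-c2ccccc2OCc2ccccc2)s1`: > 50000 nM

Compound 2 reads > 50000 nM in this assay, and this is a limit of the assay, not a number. It therefore has no exact place on the scale.

The next compound is compound 3 `O=S(=O)(NCCNC(=S)Nc1cc(C(F)(F)F)cc(C(F)(F)F)c1)c1ccc(-c2ccccc2Oc2ccc(O)c(O)c2)s1`. Its change from compound 2 is 3,4-dihydroxyphenyl in place of benzyl on an oxygen on an aromatic ring. In other words, benzyloxy gives way to 3,4-dihydroxyphenoxy.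

Going by the values given here, one measured step bears on this: an at least 4.1-fold higher number from compound 1 to compound 2 (0.61 log units; beyond the scatter). Losing that hydroxy weakened the inhibitor, so the hydroxy-bearing compound 1, with 12000 nM, is the better guide. Among the compounds with values here, compound 3 also carries hydroxy groups, but its group differs from the one in compound 1, so the comparison is only a loose one.

A step to a lower number is therefore expected, of roughly the size seen with compound 1, though compound 3 may still reach the limit. The expected change is an at least 5.0-fold lower number from compound 2 to compound 3 (0.69 log units; beyond the scatter). For compound 3, the estimate is 10000 nM, with an expected range of 2500 nM to 40000 nM.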

Compound 3, half-maximal inhibitory concentration: 10300 nM
Estimate against measurement, compound 3: 1.0-fold (0.01 log units) below, and the stated range covers the measured number.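

In this assay, putting 3,4-dihydroxyphenyl in place of benzyl on the oxygen gives an at least 4.8-fold lower number from compound 2 to compound 3 (0.68 log units; beyond the scatter), which shows that a hydroxy-bearing outer ring can lift a compound clear of the assay's limit in a second form, not only as the 3-hydroxybenzyl group of compound 1. The true size of this step is unknown, since compound 2 has only a limit of the assay and not a number: the limit of > 50000 nM in this assay, at which 1 of the 3 values shown sits.

The two hydroxy-bearing groups also give a 1.2-fold lower number from compound 1 to compound 3 (0.07 log units; within the scatter), so they cannot be told apart here, and among these compounds both that carry hydroxy groups have a measured value while the one without stays at the limit, with none going against this.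

What the compounds shown leave open is which part of the change from compound 1 to compound 3 matters, since the benzyl carbon and the second hydroxy differ together and their contributions cannot be separated. From the compounds shown here alone, it also remains open whether a phenoxy ring with a single hydroxy would do the same, or whether a methoxy group or an amine could stand in for the hydroxy.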